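The source may hold more compounds than are shown below. What is called first, only, known or untested is meant among the compounds shown, and "the series" means these compounds.

For the measured compounds named here, compound 1, with the structure `CCNc1nc(-c2ccccc2)nc2c1nnn2Cc1ccccc1`, is the only member of this small series with a number to its name: in an assay on Cerebral cortex for displacement of a labelled ligand from adenosine receptor A1 (Bos taurus) (a lower number here means a stronger inhibitor, a higher number a weaker inhibitor), compound 1 gives 91 nM. Compound 2, `CCNc1nc(-c2ccccc2)nc2c1nnn2Cc1ccccc1C(F)(F)F`, carries a trifluoromethyl group on the benzyl ring, and in this assay compound 2 gives "not determined" (no result reported), so it offers no comparison. The step in question leads to compound 3, `OCCNc1nc(-c2ccccc2)nc2c1nnn2Cc1ccccc1`, which differs from compound 1 by hydroxy in place of hydrogen on a saturated chain carbon, two bonds along the chain from a nitrogen on an aromatic ring. Going by the values given here, no pair of measured compounds shows what such a change does here, so the direction and size of the step must be estimated from the structural change alone. A modest weakening is expected for compound 3 in this assay, with the step from compound 1 to compound 3 estimated at a 2.2-fold higher number from compound 1 to compound 3 (0.34 log units; beyond the scatter), which may not exceed the ordinary scatter. The inhibition constant of compound 3 is therefore expected at 200 nM, within a range from 70 nM to 600 nM.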

Compound 3, inhibition constant: 38 nM
Beside the measured number, compound 3's estimate is 5.3-fold (0.72 log units) above it; the whole stated range lies above it.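

In this assay, the ethylamino chain of compound 1 proves open to change: going to (2-hydroxyethyl)amino gives a 2.4-fold lower number from compound 1 to compound 3 (0.38 log units; beyond the scatter) and so strengthens binding rather than weakening it. For the compounds shown here, this is the first measured information about this position, since compound 2 has no number and carries its change on the benzyl ring instead. Nothing shown here accounts for the gain in terms of how the hydroxy group acts.

The compounds shown leave open whether the gain depends on the hydroxy group itself, as a methoxy group, an amine or a carboxylic acid at the same chain carbon would test, and whether a longer chain such as 3-hydroxypropyl would keep it. They also leave open whether the same step would hold with a trifluoromethyl group on the benzyl ring.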